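Changing the Chain and Piperidine End of Compound 2

This account rests on a few compounds, and the source may have more. Where it says the series, first, only, none or still open, it means among the compounds named here.

Of the compounds shown here, two with the same core have been measured so far. In a functional assay for inhibition, read by fluorescence and spectrophotometry, with a stated time of 30 h (a lower number here means a stronger inhibitor, a higher number a weaker inhibitor), compound 1 `COc1ccc(-c2cc(=O)c3ccc(OCCCCN4CCC(C)CC4)cc3o2)cc1` gives 48200 nM, and compound 2 `COc1ccc(-c2cc(=O)c3ccc(OCCCCN4CCC(CCO)CC4)cc3o2)cc1` gives 38400 nM. Compound 2 therefore stands level with compound 1, as the two values cannot be told apart.

The next compound is compound 3 `COc1ccc(-c2cc(=O)c3ccc(OCCCCCN4CCC(C)CC4)cc3o2)cc1`. The change is (4-methylpiperidin-1-yl)methyl in place of 4-(2-hydroxyethyl)piperidin-1-yl on a saturated chain carbon, four bonds along the chain from an oxygen on an aromatic ring. In words, (4-methylpiperidin-1-yl)methyl replaces 4-(2-hydroxyethyl)piperidin-1-yl on a saturated chain carbon, four bonds along the chain from an oxygen on an aromatic ring.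

Part of this change runs opposite to the only measured step, a 1.3-fold lower number from compound 1 to compound 2 (0.10 log units; within the scatter), and that step was small enough to suggest little movement. Within the data shown here, the rest of the change concerns the chain itself, and no measured compound tests that. A step beyond the scatter in this assay is therefore not expected, in either direction, although this rests on very little evidence. The expected change is a 1.1-fold lower number from compound 2 to compound 3 (0.04 log units; within the scatter). Compound 3 is estimated at 35000 nM, with an expected range of 12000 nM to 80000 nM.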

Compound 3, half-maximal inhibitory concentration: 55100 nM
Estimate against measurement, compound 3: 1.6-fold (0.20 log units) below; the range from low to high includes it.
By their numbers in this assay, from the lowest: compounds 2, 1 and 3 (each within the scatter of the next).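

Among these compounds, compound 1 and compound 3 differ only in chain length at this position, with (4-methylpiperidin-1-yl)methyl in place of 4-methylpiperidin-1-yl, so this pair gives the first direct reading of that change. In this assay the reading is small (a 1.1-fold higher number from compound 1 to compound 3 (0.06 log units; within the scatter)), which shows that, for this end group, the longer chain gives no step beyond the scatter. The change that also removes the 2-hydroxyethyl group from the piperidine is likewise small (a 1.4-fold higher number from compound 2 to compound 3 (0.16 log units; within the scatter)), so none of the three compounds can be separated from the others, and no measurement is available to explain these values.

The compounds shown leave open whether the longer chain would behave the same way with 4-(2-hydroxyethyl)piperidin-1-yl at its end, since that pairing would test the chain in the presence of the hydroxyl group. As far as these compounds go, it also remains open whether a chain longer than that of compound 3, or a morpholine or a piperazine in place of the piperidine, would move the number beyond the scatter.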